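This account rests on a few compounds, and the source may have more. Where it says the series, first, only, none or still open, it means among the compounds named here.

Series notes. Compound 1 `COc1ccc(S(=O)(=O)Nc2ccccc2CCc2ccc(C(=O)Nc3ccccc3N)cc2)cc1` gives 23 nM in a functional assay on KB cells (Homo sapiens) for antiproliferative activity, read by sulforhodamine B assay, with a stated time of 48 h; on this read-out higher numbers stand for weaker inhibition of growth and lower numbers for stronger inhibition of growth. Compound 2 `COc1cccc(S(=O)(=O)Nc2ccccc2CCc2ccc(C(=O)Nc3ccccc3N)cc2)c1` gives 462 nM in this assay, and compound 3 `Nc1ccccc1NC(=O)c1ccc(CCc2ccccc2NS(=O)(=O)c2ccc(Cl)cc2)cc1` gives 448 nM. Compound 3 therefore stands second highest of the three numbers; its value and that of compound 2 lie within the scatter of each other, while compound 1 sits well apart, with a 19-fold higher number from compound 1 to compound 3 (1.29 log units; beyond the scatter). The other measured steps are a 20-fold higher number from compound 1 to compound 2 (1.30 log units; beyond the scatter) and a 1.0-fold lower number from compound 2 to compound 3 (0.01 log units; within the scatter); all three change only the group on the sulfonyl sulfur.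

Compound 4 `Nc1ccccc1NC(=O)c1ccc(CCc2ccccc2)cc1` differs from compound 3 in one place: hydrogen in place of ((4-chlorophenyl)sulfonyl)amino on an aromatic carbon. For the measured compounds named here, no measured step removes this group, so none bears on the change directly. What the steps do show is that the group on the sulfonyl sulfur controls a large part of the number, since a 20-fold higher number from compound 1 to compound 2 (1.30 log units; beyond the scatter) and a 19-fold higher number from compound 1 to compound 3 (1.29 log units; beyond the scatter) are both large. Taking the whole group away is thus expected to move the number further up in this assay, beyond the scatter, as a 5.6-fold higher number from compound 3 to compound 4 (0.75 log units; beyond the scatter). Compound 4 is estimated at 2500 nM, with a range from 600 nM to 10000 nM.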

Compound 4, concentration for 50% growth inhibition: > 10000 nM
Compound 4 gave a limit, no number; the forecaster's own chance of this, stated with the estimate: 15%; at least 4.0-fold (0.60 log units) between middle value and limit.
By their numbers in this assay, from the lowest: compound 1; then compounds 3 and 2 (each within the scatter of the next). At a limit, above all of these: compound 4.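

In this assay compound 4 gives > 10000 nM, which is a limit of the assay and not a number. Hydrogen in place of ((4-chlorophenyl)sulfonyl)amino gives an at least 22-fold higher number from compound 3 to compound 4 (1.34 log units; beyond the scatter), hydrogen in place of ((3-methoxyphenyl)sulfonyl)amino gives an at least 21-fold higher number from compound 2 to compound 4 (1.33 log units; beyond the scatter), and hydrogen in place of ((4-methoxyphenyl)sulfonyl)amino gives an at least 430-fold higher number from compound 1 to compound 4 (2.63 log units; beyond the scatter). For the compounds shown here, the earlier compounds showed only that the group on the sulfonyl sulfur moves the number, whereas these steps show that all three sulfonylamino compounds stand well apart from the compound carrying hydrogen on this aromatic carbon.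

As far as these compounds go, whether a simple amine or an acetamide on this carbon would stay nearer the sulfonylamino compounds or nearer compound 4 remains open. From the compounds shown here alone, the full size of these steps also remains open, as the value of compound 4 is only a limit.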